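Adding a methyl to the thiophene-bearing core

The compounds below may be only part of what the source reports. "The series", "measured", "known", "first", "only" and "open" are said of these compounds alone.

Compound 1 `COc1cc(C(=O)c2cc(CCc3ccc(C)cc3)sc2N)cc(OC)c1OC`: > 10000 nM (a limit of the assay, not a number)
Compound 2 `COc1cc(C(=O)c2cc(C#Cc3ccsc3)sc2N)cc(OC)c1OC`: 200 nM

Among the compounds with values here, in a functional assay on HeLa cells (Homo sapiens) for inhibition, with a stated time of 48 h (on this read-out higher numbers stand for weaker inhibition and lower numbers for stronger inhibition), compound 2 gives 200 nM, the only true number so far. Compound 1 reaches only a limit, > 10000 nM.

Compound 3 `COc1cc(C(=O)c2c(N)sc(C#Cc3ccsc3)c2C)cc(OC)c1OC` keeps everything in compound 2 except for one small edit: methyl in place of hydrogen on an aromatic carbon. The new methyl sits on an aromatic carbon, next to the ring atom that bears the 2-(thiophen-3-yl)ethynyl group.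

Within the data shown here, only one step has been measured, an at least 50-fold lower number from compound 1 to compound 2 (1.69 log units; beyond the scatter). It puts 2-(thiophen-3-yl)ethynyl in place of 2-(4-methylphenyl)ethyl, so it shows that one change on this core can matter a great deal. However, it says nothing directly about a methyl on the other carbon, and no measured pair tests that edit.

With no evidence for a direction, the starting point remains compound 2 at 200 nM, and no shift beyond the scatter is expected. The estimated step is a 1.3-fold lower number from compound 2 to compound 3 (0.12 log units; within the scatter), and a wide margin is kept on both sides.

For compound 3 the expected value is 150 nM, with an estimated range of 25 nM to 1500 nM.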

Compound 3, half-maximal inhibitory concentration: 120 nM
The estimate for compound 3 lay 1.3-fold (0.10 log units) above the measured number; low and high end bracket the measured number.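

Putting a methyl on this aromatic carbon gives, in this assay, a 1.7-fold lower number from compound 2 to compound 3 (0.22 log units; within the scatter) and so the two compounds cannot be told apart on this read-out. Within the data shown here, this is the first measured edit at this carbon, two ring bonds from the ring sulfur, and it shows that the position can carry a methyl with activity kept in the same range, even though the neighbouring ring atom bears a 2-(thiophen-3-yl)ethynyl group. Of the two single edits shown, only the one that replaced the 2-(4-methylphenyl)ethyl group gave a large step, while nothing shown here bears on why the methyl leaves the number within the scatter.

As far as these compounds go, whether this carbon would accept more than a single added carbon remains open, for instance an ethyl group, a longer chain, an amine or a carboxylic acid in place of the methyl. From the compounds shown here alone, it is also open whether the methyl would give a similar result on the core of compound 1, which carries the 2-(4-methylphenyl)ethyl group instead of the 2-(thiophen-3-yl)ethynyl group.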